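This account rests on a few compounds, and the source may have more. Where it says the series, first, only, none or still open, it means among the compounds named here.

In a functional assay on HT-29 cells (Homo sapiens) for antiproliferative activity, read by sulforhodamine B assay, with a stated time of 48 h (a higher number here means a weaker inhibitor, a lower number a stronger inhibitor), compound 1 `Cc1cccc(OS(=O)(=O)c2ccc(N3CCN(C)C3=O)cc2)c1` gives 4300 nM, the middle of the three measured values. Compound 2 `CN1CCN(c2ccc(S(=O)(=O)Oc3cccc([N+](=O)[O-])c3)cc2)C1=O` gives 26000 nM, and compound 3 `COc1cc(OC)cc(OS(=O)(=O)c2ccc(N3CCN(C)C3=O)cc2)c1` gives 190 nM. Compound 4 `Cc1ccc(OS(=O)(=O)c2ccc(N3CCN(C)C3=O)cc2)cc1` has the same atoms as compound 1, joined differently, with 4-methylphenyl in place of 3-methylphenyl on an oxygen. Within the data shown here, the only measured step is a 6.0-fold higher number from compound 1 to compound 2 (0.78 log units; beyond the scatter), with nitro in place of methyl on an aromatic carbon. Among the measured compounds shown here, it bears only loosely on this change, as compound 4 keeps the methyl group and no measured step relocates a group. The data favour no direction in this assay, and the expected step is a 1.2-fold lower number from compound 1 to compound 4 (0.09 log units; within the scatter), not beyond the scatter. Compound 4 is estimated at 3500 nM, with an expected range of 900 nM to 14000 nM.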

Compound 4, half-maximal inhibitory concentration: > 100000 nM
Compound 4: only a limit was reported; the forecaster's own chance of this, stated with the estimate: 3%; at least 28-fold (1.45 log units) between middle value and limit.
By their numbers in this assay, from the lowest: compound 3; then compound 1; then compound 2. At a limit, above all of these: compound 4.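

In this assay the place of the methyl group alone decides much of the result: with no atom gained or lost, 4-methylphenyl in place of 3-methylphenyl on an oxygen gives an at least 23-fold higher number from compound 1 to compound 4 (1.36 log units; beyond the scatter). Among these compounds, the earlier compounds showed only that replacing the methyl group changes the number, not that relocating it does. The entry for compound 4 is a limit, not a number: the limit of > 100000 nM in this assay, at which 1 of the 4 values shown sits. The compounds shown leave open how an ethyl group, a chlorine or an amine would fare in place of the methyl group of compound 4.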